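The source may report more compounds than this note shows. Statements on the series, on what has been measured and on what is new or still open speak of the compounds shown alone.

Three compounds have been measured:

compound 1 `O=C(/C=C/c1ccccc1Cl)Nc1ccc2ncnc(Nc3cccc(Br)c3)c2c1` gives 6.63 ug/mL in a functional assay on A549 cells (Homo sapiens) for antiproliferative activity, read by MTT assay, with a stated time of 48 h; on this read-out lower numbers stand for stronger inhibition and higher numbers for weaker inhibition
compound 2 `O=C(/C=C/c1ccc(Br)cc1)Nc1ccc2ncnc(Nc3cccc(Br)c3)c2c1` gives 15.3 ug/mL in this assay
compound 3 `O=C(/C=C/c1cccs1)Nc1ccc2ncnc(Nc3cccc(Br)c3)c2c1` gives 4.66 ug/mL in this assay

Compound 3 has the lowest number of the three. Its nearest neighbour is compound 1, separated by a 1.4-fold lower number from compound 1 to compound 3 (0.15 log units; within the scatter), which is within the scatter, so the two cannot be ordered. Compound 2 is the furthest away, separated by a 3.3-fold lower number from compound 2 to compound 3 (0.52 log units; beyond the scatter), a modest step beyond the scatter.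

Compound 4 `O=C(/C=C/c1ccc([N+](=O)[O-])cc1)Nc1ccc2ncnc(Nc3cccc(Br)c3)c2c1` is not yet measured. The change from compound 3 is 4-nitrophenyl in place of thiophen-2-yl on a double-bonded chain carbon bound to a double-bonded chain carbon. Among the measured compounds shown here, two measured steps bear on it: a 3.3-fold lower number from compound 2 to compound 3 (0.52 log units; beyond the scatter), where a 4-bromophenyl gave way to thiophen-2-yl with a modest fall, and a 1.4-fold lower number from compound 1 to compound 3 (0.15 log units; within the scatter), where 2-chlorophenyl gave way to thiophen-2-yl without a step beyond the scatter. Compound 4 moves the other way, from thiophen-2-yl back to a six-membered carbon ring carrying a group in the 4-position, as compound 2 does. For the measured compounds named here, a modest rise is therefore expected, though the 4-nitrophenyl has no direct precedent here. Compound 4 is estimated at 10 ug/mL in this assay, within 4 ug/mL to 25 ug/mL, which means an expected step of a 2.1-fold higher number from compound 3 to compound 4 (0.33 log units; beyond the scatter).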

Compound 4, half-maximal inhibitory concentration: 1.85 ug/mL
The estimate for compound 4 lay 5.4-fold (0.73 log units) above the measured number, and the stated range ends above it.
By their numbers in this assay, from the lowest: compound 4; then compounds 3 and 1 (each within the scatter of the next); then compound 2.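

In this assay, the two phenyl groups substituted at the 4-position do not behave alike: nitro in place of bromo on an aromatic carbon gives an 8.3-fold lower number from compound 2 to compound 4 (0.92 log units; beyond the scatter), the largest step among the compounds shown, so the group carried on the ring matters here and not the ring alone. The 4-nitrophenyl also goes past the two groups that could not be ordered, with a 2.5-fold lower number from compound 3 to compound 4 (0.40 log units; beyond the scatter) against thiophen-2-yl and a 3.6-fold lower number from compound 1 to compound 4 (0.55 log units; beyond the scatter) against 2-chlorophenyl, which leaves compound 4 with the lowest number of the four and with its steps to all the others beyond the scatter. Nothing among the data shown accounts for this order.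

The compounds shown leave open whether the low number belongs to nitro alone or would also come with an amine, a nitrile or a methoxy group on the same aromatic carbon. From the compounds shown here alone, whether the order of the four would hold in any other cell line also stays open.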